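Ethylamino in Place of Methyl: Estimating Compound 4

The compounds below may be only part of what the source reports. "The series", "measured", "known", "first", "only" and "open" are said of these compounds alone.

Measured compounds:
compound 1, `C[C@H](O)CNc1cc(Oc2ccc(NC(=O)Nc3cccc(C(F)(F)F)c3)cc2)ncn1`, 32 nM
compound 2, `CN(C)c1cc(Oc2ccc(NC(=O)Nc3cccc(C(F)(F)F)c3)cc2)ncn1`, 2500 nM
compound 3, `Cc1cc(Oc2ccc(NC(=O)Nc3cccc(C(F)(F)F)c3)cc2)ncn1`, 160 nM

All three numbers come from an assay on isolated protein for inhibition of serine/threonine-protein kinase TNNI3K (Homo sapiens); a higher number here means a weaker inhibitor, a lower number a stronger inhibitor. Compound 3 holds the second highest of the three values: its nearest neighbour is compound 1, reached by a 5.0-fold higher number from compound 1 to compound 3 (0.70 log units; beyond the scatter) read in reverse, and furthest from it is compound 2, as a 16-fold lower number from compound 2 to compound 3 (1.19 log units; beyond the scatter) shows.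

Compound 4, `CCNc1cc(Oc2ccc(NC(=O)Nc3cccc(C(F)(F)F)c3)cc2)ncn1`, differs from compound 3 in one place: ethylamino in place of methyl on an aromatic carbon.

Among the measured compounds shown here, two measured steps bear on this change. Going from the (2-hydroxypropyl)amino group of compound 1 to the methyl of compound 3 gave a 5.0-fold higher number from compound 1 to compound 3 (0.70 log units; beyond the scatter), so a nitrogen-linked group carrying a hydrogen-bond donor sat with the lower number. Going instead to dimethylamino gave a 78-fold higher number from compound 1 to compound 2 (1.89 log units; beyond the scatter), the largest loss in the set, and compound 2 lacks such a donor. Ethylamino brings the donor back while dropping the hydroxyl of compound 1, so the expected movement from compound 3 is toward a lower number, most likely by a modest amount, estimated as a 3.6-fold lower number from compound 3 to compound 4 (0.55 log units; beyond the scatter).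

The estimate for compound 4 in this assay is therefore 45 nM, with a range from 15 nM to 130 nM.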

Compound 4, half-maximal inhibitory concentration: 25 nM
Compound 4: the middle estimate sits 1.8-fold (0.26 log units) above what was measured, within the range that was stated.
By their numbers in this assay, from the lowest: compounds 4 and 1 (each within the scatter of the next); then compound 3; then compound 2.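

In this assay, putting ethylamino in place of methyl on this aromatic carbon, next to the ring nitrogen, gave a 6.4-fold lower number from compound 3 to compound 4 (0.81 log units; beyond the scatter) and so showed directly that this position accepts a nitrogen-linked chain in place of a small carbon group. The nitrogen link alone does not settle the outcome, since compound 2 also carries a nitrogen-linked group, yet the change from its dimethylamino to ethylamino gave a 100-fold lower number from compound 2 to compound 4 (2.00 log units; beyond the scatter) and marks this as the steepest difference among the compounds shown. The hydroxyl-bearing end of the chain in compound 1 also proves unnecessary for holding the number in this set, as replacing 1-hydroxyethyl with methyl on the chain gave a 1.3-fold lower number from compound 1 to compound 4 (0.11 log units; within the scatter) and left the two compounds indistinguishable.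

The compounds shown leave open how far this side chain can be changed, for example whether methylamino, a longer chain such as butylamino, or a cyclopropylamino group would keep the number of compound 4. No supporting evidence is available to explain why these groups differ at this position.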